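One Ring Swap, Measured Twice in a Cytotoxicity Series

A few compounds are considered here, and "the series" means these few. Any claim that something is new, unique, unknown or untested is made for them only; others in the source may bear on it.

Three compounds have so far been measured in a functional assay on L5178Y cells (Mus musculus) for cytotoxicity, read by MTT assay; on this read-out lower numbers stand for stronger inhibition and higher numbers for weaker inhibition:

Compound 1, `CCC(C)(C)c1ccc(OCCCCN2CCN(c3cccnc3)CC2)cc1`: 9.23 nM
Compound 2, `CCC(C)(C)c1ccc(OCCCCN2CCN(c3cnccn3)CC2)cc1`: 12.6 nM
Compound 3, `CC(C)(C)c1ccc(OCCCCN2CCN(c3cccnc3)CC2)cc1`: 11.7 nM

All three share a long chain that links a substituted benzene ring to a six-membered ring holding two nitrogens, the far nitrogen of which carries a small aromatic ring. Compound 3 differs from compound 1 only in the group on the benzene ring: hydrogen in place of methyl on a saturated chain carbon, two bonds along the chain from an aromatic carbon. In this assay that trimming gave a 1.3-fold higher number from compound 1 to compound 3 (0.10 log units; within the scatter), so the two cores behave alike within the usual scatter.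

The change of interest is the aromatic ring on the far nitrogen. From compound 1 to compound 2 it reads (pyrazin-2-yl in place of pyridin-3-yl on an amine nitrogen in a ring), and in this assay this produced a 1.4-fold higher number from compound 1 to compound 2 (0.14 log units; within the scatter), again a step no larger than repeated measurements of the same compound tend to differ.

Compound 4, `CC(C)(C)c1ccc(OCCCCN2CCN(c3cnccn3)CC2)cc1`, has not yet been measured. It carries the same change on the core of compound 3: pyrazin-2-yl in place of pyridin-3-yl on an amine nitrogen in a ring. The surroundings of the change are described in identical terms for both pairs, so it is the same change, not merely one of the same kind.

For compound 4 a step of a 1.4-fold higher number from compound 3 to compound 4 (0.14 log units; within the scatter) is expected, because a 1.4-fold higher number from compound 1 to compound 2 (0.14 log units; within the scatter) shows what this swap did on the neighbouring core. On that basis compound 4 is estimated at 16 nM in this assay, with a plausible range from 9 nM to 28 nM.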

Compound 4, half-maximal inhibitory concentration: 18.3 nM
For compound 4 the middle estimate is 1.1-fold (0.06 log units) below the measured one, within the range that was stated.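

In this assay, pyrazin-2-yl in place of pyridin-3-yl on the core of compound 3 gave a 1.6-fold higher number from compound 3 to compound 4 (0.19 log units; within the scatter), and this step sits close to the one seen on the other core: the same change on two cores in this assay, a 1.4-fold higher number (0.14 log units; within the scatter) from compound 1 to compound 2 and a 1.6-fold higher number (0.19 log units; within the scatter) from compound 3 to compound 4, 1.1-fold (0.06 log units) apart, within the scatter of two such steps. Hydrogen in place of methyl, read on the pyrazin-2-yl compounds, gave a 1.5-fold higher number from compound 2 to compound 4 (0.16 log units; within the scatter), and this too agrees with its earlier counterpart: the same change on two cores in this assay, a 1.3-fold higher number (0.10 log units; within the scatter) from compound 1 to compound 3 and a 1.5-fold higher number (0.16 log units; within the scatter) from compound 2 to compound 4, 1.1-fold (0.06 log units) apart, within the scatter of two such steps. Every one of these steps lies within the scatter, so the agreement shows that neither change left a readable difference on either core, not that either change has a real effect of a fixed size, and two cores that differ by a single methyl are only a narrow test of carrying a change from one core to another.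

Still open, on these data alone, is whether the ring swap would behave the same way on a core with an amine or a carboxylic acid as the group on the benzene ring, or with a shorter or longer chain linking the two ends. Also open, as far as these compounds go, is what a plain phenyl or a pyrimidinyl ring would give on the amine nitrogen in a ring.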